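Replacing the ring group of compound 2

This account rests on a few compounds, and the source may have more. Where it says the series, first, only, none or still open, it means among the compounds named here.

Compound 1 `COC(=O)C1=C(C)N=C(C)/C(=C(/O)OC)C1c1cccc(OCCO[N+](=O)[O-])c1`: 750 nM
Compound 2 `COC(=O)C1=C(C)N=C(C)/C(=C(/O)OC)C1c1cccc(OCc2no[n+]([O-])c2C)c1`: 500 nM

Both compounds were measured in a functional assay (aorta) with Rattus norvegicus as the target, in the presence of a further agent that is not named here (a lower number here means that less compound is needed, a higher number that more compound is needed for the effect), and compound 2 stands within the scatter of compound 1. Compound 3 `COC(=O)C1=C(C)N=C(C)/C(=C(/O)OC)C1c1cccc(OCc2nonc2C(N)=O)c1` carries 4-carbamoyl-1,2,5-oxadiazol-3-yl instead: a group of 8 heavy atoms (3 carbon, 3 nitrogen, 2 oxygen; one five-membered aromatic ring with 3 hetero atoms) in place of a group of 7 heavy atoms (3 carbon, 2 nitrogen, 2 oxygen; one five-membered aromatic ring with 3 hetero atoms), on a saturated chain carbon bound to an oxygen on an aromatic ring. Within the data shown here, the one measured step that bears on this, a 1.5-fold lower number from compound 1 to compound 2 (0.18 log units; within the scatter), also exchanged the group at this place, and it stayed small. This single step is thin evidence, but no shift beyond the scatter is expected in this assay, in either direction. The expected step is no change at the digits printed from compound 2 to compound 3 (within the scatter). For compound 3 the estimated value is 500 nM, with an expected range of 150 nM to 1700 nM.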

Compound 3, half-maximal effective concentration: 3500 nM
The estimate for compound 3 lay 7.0-fold (0.85 log units) below the measured number; measured number above the stated range.
By their numbers in this assay, from the lowest: compounds 2 and 1 (each within the scatter of the next); then compound 3.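

In this assay, the group on a saturated chain carbon bound to an oxygen on an aromatic ring turns out to matter: with 4-carbamoyl-1,2,5-oxadiazol-3-yl there comes a 7.0-fold higher number from compound 2 to compound 3 (0.85 log units; beyond the scatter) and a 4.7-fold higher number from compound 1 to compound 3 (0.67 log units; beyond the scatter), both beyond the scatter, whereas the earlier exchange stayed within it. So this place does not tolerate every group alike. Going by these compounds, whether the rise belongs to the carbamoyl group or to the ring that carries it stays open, and a nitrile or a carboxylic acid on the same ring would separate the two. No evidence at hand bears on why the number rose.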